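A few compounds are considered here, and "the series" means these few. Any claim that something is new, unique, unknown or untested is made for them only; others in the source may bear on it.

Series notes. Compound 3 `CCC1(CCCCN2CCN(c3ccccc3OC)CC2)C(=O)N(Cc2ccccc2)c2ccccc21` in a functional assay on the whole organism (strain Wistar) with Rattus norvegicus as the target, with a stated time of 5 min (on this read-out lower numbers stand for an effect already at smaller amounts and higher numbers for an effect only at larger amounts of compound), gives > 20 mg/kg, which is a limit of the assay and not a number. It sits at the limit of > 20 mg/kg in this assay, at which 2 of the 3 values shown sit. Compound 1 `CCC1(CCCCN2CCN(c3ccc(Cl)c(Cl)c3)CC2)C(=O)Nc2ccccc21` also gives only > 20 mg/kg as a limit. Compound 2 `CCC1(CCCCN2CCN(c3ccc(F)cc3)CC2)C(=O)Nc2ccccc21` gives 10 mg/kg. Among the compounds with values here, the single measured step, an at least 2.0-fold lower number from compound 1 to compound 2 (0.30 log units; that floor lies within the scatter), alters the group on an amine nitrogen in a ring and does not touch the amide-type nitrogen in a ring. Compound 4 `CCC1(CCCCN2CCN(c3ccccc3OC)CC2)C(=O)Nc2ccccc21` differs from compound 3 by hydrogen in place of benzyl on an amide-type nitrogen in a ring. Within the data shown here, no measured step covers that place, so no size follows from the steps; compound 2, which carries a hydrogen there, gives 10 mg/kg. Compound 4 is therefore estimated at 20 mg/kg (range 8 mg/kg to 50 mg/kg), the expected step being a number no higher from compound 3 to compound 4 (the limit leaves the size open), with a fair chance that only a limit is reported.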

Compound 4, minimum effective dose: 10 mg/kg
Compound 4: the middle estimate sits 2.0-fold (0.30 log units) above what was measured; the range from low to high includes it.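

Hydrogen in place of benzyl on the amide-type nitrogen in a ring gives the only reading at this place in this assay: an at least 2.0-fold lower number from compound 3 to compound 4 (0.30 log units; that floor lies within the scatter). With hydrogen on that nitrogen, 2-methoxyphenyl in place of 4-fluorophenyl on the amine nitrogen in a ring gives no change at the digits printed from compound 2 to compound 4 (within the scatter). 2-Methoxyphenyl in place of 3,4-dichlorophenyl gives an at least 2.0-fold lower number from compound 1 to compound 4 (0.30 log units; that floor lies within the scatter).

The true sizes of the steps from compound 1 and compound 3 stay open, as both compounds give only a limit of the assay: the limit of > 20 mg/kg in this assay, at which 2 of the 4 values shown sit.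
On these data alone, whether methyl or a longer chain on the amide-type nitrogen would behave like hydrogen or like benzyl also remains open.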